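This account rests on a few compounds, and the source may have more. Where it says the series, first, only, none or still open, it means among the compounds named here.

Working notes on a benzothiophene-free description of the series are not possible, so the cores are simply taken as they stand. Compound 1 `CS/C(=N\C(=O)c1cc2ccccc2s1)NC(=O)c1cc2ccccc2s1` and compound 2 `CS/C(=N\C(=O)c1ccco1)NC(=O)c1ccco1` share the methylsulfanyl-bearing central carbon but differ in their aroyl groups; the difference between the two cores is not broken down here. In an ADME assay on MCF-10A cells (Homo sapiens) for cytotoxicity, read by MTT assay, with a stated time of 72 h (on this read-out higher numbers stand for weaker inhibition of growth and lower numbers for stronger inhibition of growth), compound 1 gives 20 nM, while compound 2 gives 8220 nM, a gap far beyond the scatter. Compound 3 `O=C(/N=C(/NC(=O)c1ccco1)[Se]Cc1ccccc1)c1ccco1` carries on the core of compound 2 the change (a group of 8 heavy atoms (7 carbon, 1 selenium; one six-membered aromatic ring of carbon only) in place of a group of 2 heavy atoms (1 carbon, 1 sulfur; no ring), on a carbon with a double bond to nitrogen). In this assay compound 3 gives 8800 nM, so the step of a 1.1-fold higher number from compound 2 to compound 3 (0.03 log units; within the scatter) is within the scatter. Compound 4 `O=C(/N=C(/NC(=O)c1cc2ccccc2s1)[Se]Cc1ccccc1)c1cc2ccccc2s1` is not yet measured; it carries on compound 1 the change (a group of 8 heavy atoms (7 carbon, 1 selenium; one six-membered aromatic ring of carbon only) in place of a group of 2 heavy atoms (1 carbon, 1 sulfur; no ring), on a carbon with a double bond to nitrogen), the same change as from compound 2 to compound 3, made at the same place. Because the step of a 1.1-fold higher number from compound 2 to compound 3 (0.03 log units; within the scatter) was within the scatter, the step from compound 1 to compound 4 is expected to be similarly small, about a 1.3-fold higher number from compound 1 to compound 4 (0.10 log units; within the scatter). Compound 4 is therefore estimated at 25 nM in this assay, with a range of 8 nM to 80 nM.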

Compound 4, concentration for 50% growth inhibition: 37900 nM
Estimate against measurement, compound 4: 1500-fold (3.18 log units) below, and the stated range ends below it.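

In this assay, replacing methylsulfanyl with the selenium-bearing group gives a 1900-fold higher number from compound 1 to compound 4 (3.28 log units; beyond the scatter) and so does not leave the number unchanged on this core. The same change at the same place therefore does not carry from one core to the other: the same change on two cores in this assay, a 1.1-fold higher number (0.03 log units; within the scatter) from compound 2 to compound 3 and a 1900-fold higher number (3.28 log units; beyond the scatter) from compound 1 to compound 4, 1800-fold (3.25 log units) apart, beyond the scatter of two such steps. Going by these compounds alone, this shows that a step read on the core of compound 2 cannot be transferred to the core of compound 1, but with only two matched pairs it does not explain the difference between the cores or give a rule for any other core.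

The selenium atom and the six-membered aromatic ring enter together, so the compounds shown leave open which of them goes with the large step on the core of compound 1. A methylselanyl or benzylsulfanyl group on each core would separate the two, and a longer alkyl chain or an amine at the same carbon would show how far the step extends beyond these groups.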